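Stereo series: from compound 3 to compound 4

The source may hold more compounds than are shown below. What is called first, only, known or untested is meant among the compounds shown, and "the series" means these compounds.

Measured in a functional assay on A549 cells (Homo sapiens) for cytotoxicity, read by MTT assay, with a stated time of 48 h (on this read-out lower numbers stand for stronger inhibition and higher numbers for weaker inhibition), as follows:
compound 1 `CCOC(=O)[C@]1(C(=O)Nc2ccccc2)C[C@H]1c1cc(OC)c(OC)c(OC)c1` gives 37300 nM
compound 2 `CCOC(=O)[C@@]1(C(=O)Nc2ccccc2Cl)C[C@@H]1c1cc(OC)c(OC)c(OC)c1` gives 29000 nM
compound 3 `CCOC(=O)[C@]1(C(=O)Nc2ccccc2Cl)C[C@@H]1c1cc(OC)c(OC)c(OC)c1` gives 50900 nM

All three values lie close together. Compound 3 at 50900 nM sits within the scatter of both compound 1 and compound 2, so it holds no distinct place in the set.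

The next compound is compound 4 `CCOC(=O)[C@]1(C(=O)Nc2ccccc2Cl)C[C@H]1c1cc(OC)c(OC)c(OC)c1` and its relation to compound 3 is this: the two compounds have the same atoms and bonds and differ only in configuration as drawn: 1 of 2 stereo elements differ; a stereocentre at a saturated ring carbon is drawn R in compound 3 and S in compound 4 and no group leaves or enters.

One measured step is of the same kind. Going by the values given here, it is a 1.8-fold higher number from compound 2 to compound 3 (0.24 log units; within the scatter) and it bears on this change through the fact that compounds 2 and 3 differ only in the configuration as drawn as the only such pair. Among the compounds with values here, with compound 2 and compound 3 as the sole precedent, a single case within the scatter, no step beyond the scatter is expected in this assay and no direction is favoured.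

The expected step is a 1.3-fold lower number from compound 3 to compound 4 (0.10 log units; within the scatter) and it stays within the scatter.

Compound 4 is expected at 40000 nM with an estimated range from 20000 nM to 80000 nM in this assay.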

Compound 4, half-maximal inhibitory concentration: 13400 nM
For compound 4 the middle estimate is 3.0-fold (0.47 log units) above the measured one, and the stated range ends above it.
By their numbers in this assay, from the lowest: compound 4; then compounds 2, 1 and 3 (each within the scatter of the next).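

In this assay, configuration alone now gives a step beyond the scatter, a 3.8-fold lower number from compound 3 to compound 4 (0.58 log units; beyond the scatter), and the mirror-image pair does the same, a 2.2-fold lower number from compound 2 to compound 4 (0.34 log units; beyond the scatter). No group leaves or enters in either step, so the gaps are tied to the configuration as drawn: the fact that compounds 3 and 4 differ only in the configuration as drawn Within the configuration of compound 4, chloro in place of hydrogen on an aromatic carbon also counts, with a 2.8-fold lower number from compound 1 to compound 4 (0.44 log units; beyond the scatter), which puts compound 4 below all three earlier compounds by steps beyond the scatter.

Open, as far as these compounds go, is whether this configuration keeps its lower number when the chloro gives way to an amine or a carboxylic acid, or when the ethyl of the ester gives way to a longer chain. Also open is whether the gap between configurations holds without the chloro, as compound 1 is the only compound shown that lacks it.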